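From Anilino to (4-Carboxyphenyl)amino: Compound 3 to Compound 4

The compounds below may be only part of what the source reports. "The series", "measured", "known", "first", "only" and "open" are said of these compounds alone.

Three compounds have been measured in an assay on isolated protein for inhibition of CAAX prenyl protease 2 (Homo sapiens), with stated times of 60 s and 60 min; a lower number here means a stronger inhibitor, a higher number a weaker inhibitor:

Compound 1 `O=C(O)c1ccc(NC(c2ccccc2)c2ccc3ccccc3c2O)cc1` gives 4200 nM.
Compound 2 `O=C(O)c1ccc(NC(c2ccc(Br)cc2)c2ccc3ccccc3c2O)cc1` gives 3900 nM.
Compound 3 `Oc1c(C(Nc2ccccc2)c2c(F)cc(Br)cc2F)ccc2ccccc12` gives 9400 nM.

Among these three, compound 3 gives the highest number in this assay; the gap to compound 1 and the gap to compound 2 both lie beyond the scatter. The unmeasured compound 4 `O=C(O)c1ccc(NC(c2ccc3ccccc3c2O)c2c(F)cc(Br)cc2F)cc1` is reached from compound 3 by a single change: carboxy in place of hydrogen on an aromatic carbon. Going by the values given here, no measured step covers this change. Among the compounds with values here, the one step available, a 1.1-fold lower number from compound 1 to compound 2 (0.03 log units; within the scatter), concerns a bromo group on a different ring and says nothing about a carboxy group. What can be said is that compound 1 and compound 2, which both carry the carboxy group, give lower numbers in this assay than compound 3, but they also differ from compound 3 in the fluoro and bromo substitution, so the comparison is not clean. On this basis a moderate move toward a lower number is expected, a 3.1-fold lower number from compound 3 to compound 4 (0.50 log units; beyond the scatter). Compound 4 is estimated at 3000 nM in this assay, within a range from 1000 nM to 9000 nM.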

Compound 4, half-maximal inhibitory concentration: 3800 nM
For compound 4 the middle estimate is 1.3-fold (0.10 log units) below the measured one; low and high end bracket the measured number.
By their numbers in this assay, from the lowest: compounds 4, 2 and 1 (each within the scatter of the next); then compound 3.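

In this assay, going by these compounds alone, the carboxy group para to a large group now has a direct step of its own, a 2.5-fold lower number from compound 3 to compound 4 (0.39 log units; beyond the scatter), a modest change, which the earlier compounds could only hint at across differences in more than one place. With the carboxy group present, the aryl group on the saturated chain carbon makes no visible difference: 4-bromo-2,6-difluorophenyl in place of 4-bromophenyl gives a 1.0-fold lower number from compound 2 to compound 4 (0.01 log units; within the scatter), and in place of phenyl gives a 1.1-fold lower number from compound 1 to compound 4 (0.04 log units; within the scatter). No evidence is at hand that bears on this result.

The compounds shown leave open whether a methyl ester, a primary amide or a tetrazole in the same place would give a number like that of the carboxy group. They also leave open whether hydrogen to carboxy gives a step of the same size with phenyl or 4-bromophenyl in place of 4-bromo-2,6-difluorophenyl.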